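Phenyl for Methylsulfonyl: Cytotoxicity Expected to Stay Low

The source may report more compounds than this note shows. Statements on the series, on what has been measured and on what is new or still open speak of the compounds shown alone.

Of the compounds shown here, three have been tested in a toxicity assay on NIH3T3 cells (Mus musculus) for cytotoxicity, read by resazurin assay; a higher number here means that more compound is needed for the effect, a lower number that less compound is needed. Compound 1 `CC(C)c1ccc(Cn2cncc2CNc2ccc(-c3nc4ccccc4s3)c(-c3ccccc3)c2)cc1` gives > 1000 nM, which is a limit of the assay rather than a number. Compound 2 `c1ccc(-c2ccc(Cn3cncc3CNc3ccc(N4CCCC4)c(-c4ccccc4)c3)cc2)cc1` also gives only a limit, > 1000 nM. Compound 3 `CS(=O)(=O)c1ccc(Cn2cncc2CNc2ccc(-c3nc4ccccc4s3)c(-c3ccccc3)c2)cc1` likewise gives a limit, > 1000 nM. Going by the values given here, the single measured step, a step that the two limits leave unreadable from compound 1 to compound 3, therefore has no readable size. Compound 4 `c1ccc(-c2ccc(Cn3cncc3CNc3ccc(-c4nc5ccccc5s4)c(-c4ccccc4)c3)cc2)cc1` differs from compound 3 by phenyl in place of methylsulfonyl on an aromatic carbon. Among the compounds with values here, no measured step bears directly on this change, though compound 2, which also carries a phenyl, reaches only a limit in this assay. Since the limit of > 1000 nM in this assay, at which 3 of the 3 values shown sit, holds for every value shown, no step beyond the scatter is expected, and another limit is the likely outcome. Compound 4 is estimated at 3000 nM, between 1000 nM and 30000 nM, an expected step that the limit leaves unreadable from compound 3 to compound 4.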

Compound 4, half-maximal effective concentration: > 1000 nM
Compound 4: a limit, no number; the forecaster's own chance of this, stated with the estimate: 85%; the middle value lies beyond the limit too.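

Compound 4 gives [ > 1000 nM ], a limit and not a number. Its steps from compound 1, compound 2 and compound 3 cannot be read. The compounds shown leave open how much of any of them produces the effect in this assay.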